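From oxolan-3-yl to oxolan-2-yl on compound 1

A few compounds are considered here, and "the series" means these few. Any claim that something is new, unique, unknown or untested is made for them only; others in the source may bear on it.

- compound 1 `Cc1cc(C)c(CN2CCc3c(Cl)cc([C@H](CO)[C@H]4CCOC4)c(Cl)c3C2=O)c(=O)[nH]1`: 570000 nM
- compound 2 `COC(c1cc(Cl)c2c(c1Cl)C(=O)N(Cc1c(C)cc(C)[nH]c1=O)CC2)C1CCOC1`: 415000 nM; 457000 nM; 439000 nM; 436000 nM (4 entries)

Among the measured compounds shown here, in a physicochemical assay for solubility, measured as kinetic solubility (a lower number here means a less soluble compound, a higher number a more soluble compound), compound 1 gives 570000 nM, the only single number available for it, since one further entry came without one. Compound 2 was measured repeatedly, and its readings sit close together: the several entries of compound 2 in this assay, 415000 nM; 457000 nM; 439000 nM; 436000 nM (4 entries). The values of compound 1 and compound 2 lie within the usual scatter of each other, so they cannot be ranked.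

The next compound is compound 3 `Cc1cc(C)c(CN2CCc3c(Cl)cc([C@H](CO)[C@H]4CCCO4)c(Cl)c3C2=O)c(=O)[nH]1`. It has the same atoms as compound 1, joined differently: oxolan-2-yl stands in place of oxolan-3-yl on a saturated chain carbon bound to an aromatic carbon and a saturated chain carbon (oxolan-2-yl in place of oxolan-3-yl on a saturated chain carbon bound to an aromatic carbon and a saturated chain carbon). For the measured compounds named here, no measured pair shows this swap on its own, so there is no direct precedent for it. In this assay no change beyond the scatter is expected, and no direction is favoured. The estimate therefore stays close to compound 1 at 570000 nM. The expected 1.1-fold lower number from compound 1 to compound 3 (0.06 log units; within the scatter) is a small, estimated shift. For compound 3 the expected value is 500000 nM, with an estimated range of 280000 nM to 850000 nM.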

Compound 3, solubility: 430000 nM
Compound 3: middle estimate off by 1.2-fold (0.07 log units), on the high side, and the stated range covers the measured number.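

In this assay, putting oxolan-2-yl in place of oxolan-3-yl on a saturated chain carbon bound to an aromatic carbon and a saturated chain carbon gives a 1.3-fold lower number from compound 1 to compound 3 (0.12 log units; within the scatter). Among the compounds shown here, this is the first measured step at this place, and it shows that the two ring attachments, which have the same atoms and the same counts of donors and acceptors, cannot be ranked in this read-out, so compound 1 and compound 3 count as equal here. How closely repeat readings of a single compound agree gives a feel for what such a step is worth: the several entries of compound 2 in this assay, 415000 nM; 457000 nM; 439000 nM; 436000 nM (4 entries)

Both rings are five-membered oxolane rings, so this single step says only that moving the attachment point around that ring left the number within the scatter, and it says nothing about a different kind of group at this place. As far as these compounds go, whether an amine such as a piperidine ring, a carboxylic acid or a longer open chain on this carbon would also stay within the scatter remains open, as does the effect of the opposite arrangement at the defined stereocentres.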